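The compounds below may be only part of what the source reports. "The series", "measured", "known", "first", "only" and "open" are said of these compounds alone.

Within the data shown here, compound 1 `Cc1nc(SCC(=O)Nc2nc(-c3ccc(Cl)cc3)cs2)n(Nc2ccccc2)c1C` gives 49800 nM in a functional assay on COLO 205 cells (Homo sapiens) for antiproliferative activity, read by sulforhodamine B assay, with a stated time of 48 h (on this read-out higher numbers stand for lower toxicity in this test and lower numbers for higher toxicity in this test), the only number in the set. Compound 2 `Cc1ccc(Nn2c(SCC(=O)Nc3nc(-c4ccccc4)cs3)nc(C)c2C)cc1` reaches only the assay limit in this assay, reported as > 100000 nM. Of the two values shown, one therefore sits at a limit (the limit of > 100000 nM in this assay, at which 1 of the 2 values shown sits). Among the measured compounds shown here, no step between two measured compounds is available. Compound 3 `COc1ccc(Nn2c(SCC(=O)Nc3nc(-c4ccc(Cl)cc4)cs3)nc(C)c2C)cc1` keeps the remainder of compound 1 unchanged and differs by methoxy in place of hydrogen on an aromatic carbon. The expected 1.4-fold higher number from compound 1 to compound 3 (0.15 log units; within the scatter) is small, within the scatter or tending toward lower toxicity, since compound 1 already sits at 49800 nM. Compound 3 is estimated at 70000 nM, range 25000 nM to 200000 nM.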

Compound 3, concentration lethal to 50% of the cells: 6510 nM
The estimate for compound 3 lay 11-fold (1.03 log units) above the measured number; the whole stated range lies above it.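

Methoxy in place of hydrogen on this aromatic carbon, para to a large group, is not a silent change in this assay: it gives a 7.6-fold lower number from compound 1 to compound 3 (0.88 log units; beyond the scatter). This position therefore responds to substitution, and the change moves toward higher toxicity in this test. Nothing available accounts for the size of this step.

As far as these compounds go, whether an amine, a carboxylic acid or a longer chain such as ethoxy at the same place would move the number in the same direction remains open. Also open, from the compounds shown here alone, is whether the step carries over to other compounds.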